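Swapping the acid-bearing ring for a hydroxy chain

The compounds below may be only part of what the source reports. "The series", "measured", "known", "first", "only" and "open" are said of these compounds alone.

Compound 1 `CC(C)(C)NS(=O)(=O)c1ncc(-c2sc(C(=O)N[C@H]3C[C@H](C(=O)O)C3)nc2CC2CCCCC2)c2ccccc12` is measured in an ADME assay on microsomes (Homo sapiens) for metabolic stability (a higher number here means that the compound lasts longer, a lower number that the compound disappears faster), where compound 1 gives 1.28 h. That is the highest of the two numbers seen so far; the nearest is compound 2 `CC(C)(O)CNC(=O)c1nc(CC2CCCCC2)c(-c2ccc(S(=O)(=O)NC(C)(C)C)c(Cl)c2C(F)F)s1`, which in this assay gives 0.3 h, a gap beyond the usual scatter. Compound 3 `CC(C)(O)CNC(=O)c1nc(CC2CCCCC2)c(-c2cnc(S(=O)(=O)NC(C)(C)C)c3ccccc23)s1` has not yet been measured in this assay. It differs from compound 1 in one place: 2-hydroxy-2-methylpropyl in place of 3-carboxycyclobutyl on an amide-type nitrogen. Going by the values given here, no measured pair shows exactly this step, so any guess rests on compound 2, which carries the same 2-hydroxy-2-methylpropyl group on its amide and gives 0.3 h. A drop beyond the scatter is therefore expected, the step from a 2.6-fold lower number from compound 1 to compound 3 (0.41 log units; beyond the scatter) being the estimate. In this assay compound 3 is expected to give about 0.5 h, most likely between 0.2 h and 1.3 h.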

Compound 3, half-life in the Homo sapiens assay: 0.383 h
For compound 3 the middle estimate is 1.3-fold (0.12 log units) above the measured one; the measured number falls inside the stated range.
By their numbers in the Homo sapiens assay, from the lowest: compounds 2 and 3 (each within the scatter of the next); then compound 1.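

Going by these compounds alone, on the shared core, the only change from compound 1 to compound 3 is on the amide-type nitrogen, so the Homo sapiens assay now gives a direct reading of this swap, with compound 3 at 0.383 h. Putting 2-hydroxy-2-methylpropyl in place of 3-carboxycyclobutyl brings a 3.3-fold lower number from compound 1 to compound 3 (0.52 log units; beyond the scatter), which is a step beyond the usual scatter that compound 2, differing from compound 1 in more than one place, could not isolate. In a physicochemical assay for solubility, read by HPLC, in phosphate buffer, measured as thermodynamic solubility, with a stated time of 5 days, at pH 2, tested at 10 mM (a higher number here means a more soluble compound, a lower number a less soluble compound), compound 1 gives < 1000 nM, which is a limit of the assay and not a number. In the physicochemical assay compound 3 gives < 4000 nM, which is also a limit of the assay and not a number. With only limits on both sides, the step there cannot be read.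

The swap removes the ring and the carboxylic acid together, so the result cannot say which of the two matters for the lower number. It also leaves open how this position would behave with a plain cyclobutyl group, a 3-aminocyclobutyl group or a longer hydroxy chain.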